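From methyl to 4-methoxyphenyl on a sulfonyl sulfur

The source may report more compounds than this note shows. Statements on the series, on what has been measured and on what is new or still open speak of the compounds shown alone.

Three compounds have been measured so far in a functional assay on the whole organism for inhibition, with Rattus norvegicus as the target (a higher number here means that more compound is needed for the effect, a lower number that less compound is needed), as follows:
- Compound 1 `COc1ccccc1CC(Oc1ccc(C(C)C)cc1)C(=O)O` gives > 10 mg/kg as a limit of the assay, not a number
- Compound 2 `CC(Cc1ccc(Cl)cc1)(Oc1ccc(Cc2ccccc2)cc1)C(=O)O` gives 1 mg/kg as its value
- Compound 3 `CC(C)c1ccc(OC(C)(Cc2ccc(Cl)cc2)C(=O)NS(C)(=O)=O)cc1` gives 5 mg/kg as its value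

Only two of these results are true numbers. Compound 3 has the higher of the two, and its gap to compound 2 lies beyond the usual scatter, so more of compound 3 is needed for the effect.

The next compound, compound 4 `COc1ccc(S(=O)(=O)NC(=O)C(C)(Cc2ccc(Cl)cc2)Oc2ccc(C(C)C)cc2)cc1`, carries 4-methoxyphenyl in place of methyl on a sulfonyl sulfur. Within the data shown here, no measured pair of compounds isolates this change, so any forecast is a judgement. The nearest guide is the range of the two numbers, with compound 2 at 1 mg/kg and compound 3 at 5 mg/kg as its ends. In this assay a small move toward a lower number is expected, probably not clearly beyond the scatter. The expected change is a 1.7-fold lower number from compound 3 to compound 4 (0.22 log units; within the scatter) as a rough estimate. The estimate for compound 4 is 3 mg/kg as a middle value, with an expected range from 1 mg/kg up to 10 mg/kg in this assay.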

Compound 4, dose for half-maximal effect: > 10 mg/kg
Compound 4: only a limit was reported; the forecaster's own chance of this, stated with the estimate: 15%; at least 3.3-fold (0.52 log units) between middle value and limit.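

Compound 3 and compound 4 are the first pair shown that differ in one place, so they give the first direct reading of the group on the sulfonyl sulfur in this assay. From the compounds shown here alone, replacing methyl with 4-methoxyphenyl gives an at least 2.0-fold higher number from compound 3 to compound 4 (0.30 log units; that floor lies within the scatter), so the added ring and its methoxy bring no gain at this position, but the true size of the change stays unknown: only a floor can be read, and that floor does not clear the scatter. Compound 4 gives > 10 mg/kg, which is a limit of the assay and not a number, and that limit is shared: the limit of > 10 mg/kg in this assay, at which 2 of the 4 values shown sit.

The compounds shown leave open whether the ring or its methoxy goes with the higher number, a question that plain phenyl on the sulfonyl sulfur would address. They also leave open how the number responds to a small step up from methyl, such as ethyl, and so whether a group between these two sizes would keep a measurable value.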